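A few compounds are considered here, and "the series" means these few. Any claim that something is new, unique, unknown or untested is made for them only; others in the source may bear on it.

Measured in an ADME assay on MT4 cells (Homo sapiens) for cytotoxicity, read by MTT assay, with a stated time of 5 days; on this read-out lower numbers stand for higher toxicity in this test and higher numbers for lower toxicity in this test:
Compound 1 `Cc1cc(C#N)cc(C)c1Oc1cc(Nc2ccc(C#N)cc2)[nH]c(=O)c1Cl`: > 319000 nM
Compound 2 `Cc1cc(C)c(Oc2cc(Nc3ccc(C#N)cc3)[nH]c(=O)c2I)c(C)c1`: 34000 nM

Among the measured compounds shown here, compound 2 gives the only actual number so far, 34000 nM. Compound 1 stands at > 319000 nM, which is a limit of this assay and not a number.

Compound 3 `Cc1cc(C#N)cc(C)c1Oc1cc(Nc2ccc(C#N)cc2)[nH]c(=O)c1I` has not yet been measured. It differs from compound 2 by a single change: cyano in place of methyl on an aromatic carbon, para to a large group and meta to two methyl groups (cyano in place of methyl on an aromatic carbon). For the measured compounds named here, no measured pair shows this change alone, so the expectation is tentative. In this assay a moderate rise is expected, pointing to lower toxicity in this test. That expectation leans on compound 1, which also carries cyano in that place and shows > 319000 nM, again a limit. The estimated step is a 2.6-fold higher number from compound 2 to compound 3 (0.42 log units; beyond the scatter). Compound 3 is estimated at 90000 nM, with an expected range from 25000 nM to 260000 nM.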

Compound 3, half-maximal cytotoxic concentration: > 259000 nM
Compound 3: only a limit was reported (the forecaster's own chance of this, stated with the estimate: 35%); at least 2.8-fold (0.45 log units) between middle value and limit.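

In this assay, cyano in place of methyl on an aromatic carbon, para to a large group and meta to two methyl groups, now has a measured pair behind it and gives an at least 7.6-fold higher number from compound 2 to compound 3 (0.88 log units; beyond the scatter), which points to lower toxicity in this test for this change alone. Compound 3 gives a limit and not a number, so the step has a floor but no known size: the limit of > 259000 nM in this assay, at which 1 of the 3 values shown sits. Compound 1 also gives a limit, and the step between it and compound 3, iodo in place of chloro, cannot be read: the limit of > 319000 nM in this assay, at which 1 of the 3 values shown sits.

The compounds shown leave open how large the cyano step really is, and whether iodo and chloro differ at all with cyano in this place. They also leave open how an amine or a carboxylic acid at this same place would stand in this assay.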